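The compounds below may be only part of what the source reports. "The series", "measured", "known", "first", "only" and "open" are said of these compounds alone.

Three measured compounds share one core, an amide-linked aminophenyl group joined through a benzylic sulfur to a thiocarbonyl carbon, and differ only in the nitrogen group on that carbon. Compound 1 `CN(C(=S)SCc1ccc(C(=O)Nc2ccccc2N)cc1)c1cccnc1` carries methyl(pyridin-3-yl)amino there; in a functional assay on MGC-803 cells (Homo sapiens) for antiproliferative activity, read by CCK-8 assay, with a stated time of 72 h, tested at 8 uM (on this read-out lower numbers stand for a weaker effect and higher numbers for a stronger effect at the one concentration tested), compound 1 gives 82.5%. Compound 2 `Nc1ccccc1NC(=O)c1ccc(CSC(=S)N2CCc3cc(Cl)ccc32)cc1` carries 5-chloro-2,3-dihydro-1H-indol-1-yl, and in this assay compound 2 gives 82.2%. Compound 3 `CCN(Cc1ccncc1)C(=S)SCc1ccc(C(=O)Nc2ccccc2N)cc1` carries ethyl((pyridin-4-yl)methyl)amino, and in this assay compound 3 gives 85.2%. Compound 3 sits within the scatter of both companions: the change is a number 2.7 percentage points higher from compound 1 to compound 3 (within the scatter) and a number 3 percentage points higher from compound 2 to compound 3 (within the scatter), while the remaining pair shows a number 0.3 percentage points lower from compound 1 to compound 2 (within the scatter). Every swap at the thiocarbonyl carbon so far has left the read-out essentially unchanged.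

Compound 4 `CC1CCN(C(=S)SCc2ccc(C(=O)Nc3ccccc3N)cc2)CC1` continues this series. 4-methylpiperidin-1-yl in place of ethyl((pyridin-4-yl)methyl)amino on a thiocarbonyl carbon

All three measured steps bear on this change, since each replaces the nitrogen group on the thiocarbonyl carbon, and all three stayed within the scatter. The expectation is therefore no step beyond the scatter, the estimated change being a number 4.2 percentage points lower from compound 3 to compound 4 (within the scatter). In this assay compound 4 is expected to give about 81%, with a range from 66% to 91%.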

Compound 4, a percentage reported as inhibition, at one concentration (the size of the read-out at that concentration, not a potency): 81.9%
For compound 4 the middle estimate is 0.9 percentage points below the measured one; low and high end bracket the measured number.
By their numbers in this assay, from the lowest: compounds 4, 2, 1 and 3 (each within the scatter of the next).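

At the place on a thiocarbonyl carbon, 4-methylpiperidin-1-yl brings a six-membered non-aromatic ring and no hydrogen-bond acceptor in place of the aromatic ring of ethyl((pyridin-4-yl)methyl)amino, and this assay shows a number 3.3 percentage points lower from compound 3 to compound 4 (within the scatter). The comparisons with the other two groups, each of which also carries an aromatic ring, agree, with a number 0.3 percentage points lower from compound 2 to compound 4 (within the scatter) and a number 0.6 percentage points lower from compound 1 to compound 4 (within the scatter), so among these four compounds an aromatic ring in this group is not needed for the read-out to stay where it is. Nothing measured here explains why such different groups read alike.

Whether a nitrogen group bearing a carboxylic acid or a much longer alkyl chain would also leave the read-out in place remains open, since every group shown so far is uncharged and of modest size. Also open, going by these compounds, is whether these compounds would differ in the strength of their effect at lower concentrations, as this assay reports the effect at one concentration only and cannot show differences that would appear there.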